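The source may report more compounds than this note shows. Statements on the series, on what has been measured and on what is new or still open speak of the compounds shown alone.

Three related compounds have been measured in a functional assay on HeLa cells (Homo sapiens) for inhibition, read by MTT assay, with a stated time of 72 h; on this read-out higher numbers stand for weaker inhibition and lower numbers for stronger inhibition. Compound 1 (`O=C(Nc1ccc(Nc2ncnc3[nH]ncc23)cc1)Nc1ccc(C(F)(F)F)cc1`) reads > 10000 nM, which is a limit and not a number. Compound 2 (`O=C(Nc1ccc(Oc2ncnc3[nH]ncc23)cc1)Nc1ccc(C(F)(F)F)cc1`) reads > 10000 nM, which is also a limit. Compound 3 (`O=C(Nc1ccc(C(F)(F)F)cc1)Nc1cccc(Oc2ncnc3[nH]ncc23)c1`) reads > 10000 nM, again a limit. Compound 2 therefore has no exact place on the scale and stands with the other two at the limit of > 10000 nM in this assay, at which 3 of the 3 values shown sit.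

The unmeasured compound 4 (`O=C(NCC1CCCCC1)Nc1ccc(Oc2ncnc3[nH]ncc23)cc1`) differs from compound 2 in one group: cyclohexylmethyl in place of 4-(trifluoromethyl)phenyl on an amide-type nitrogen, (cyclohexylmethyl in place of 4-(trifluoromethyl)phenyl on an amide-type nitrogen). A six-membered aromatic ring of carbon only thus gives way to a six-membered non-aromatic ring of carbon only.

The one measured step among these compounds, a step that the two limits leave unreadable from compound 1 to compound 2, has no readable size and does not touch this group. Within the data shown here, no measured compound varies this group, so the data offer no size to carry over. Among the measured compounds shown here, with the limit of > 10000 nM in this assay, at which 3 of the 3 values shown sit, as the only guide, no readable step is expected, and a further limit is the likeliest result. The expected change is a step that the limit leaves unreadable from compound 2 to compound 4, and the data support no firm direction for it. The estimated value for compound 4 is 15000 nM, expected to fall between 4000 nM and 50000 nM.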

Compound 4, half-maximal inhibitory concentration: > 10000 nM
Compound 4 was reported as a limit; the forecaster's own chance of this, stated with the estimate: 70%; the middle value does not contradict the limit.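

Compound 2 and compound 4 are both reported as limits in this assay, not as numbers, so the step of cyclohexylmethyl in place of 4-(trifluoromethyl)phenyl cannot be read. The compounds shown leave open whether any change to the group on this amide-type nitrogen would give a readable number, and every value so far sits at one limit: the limit of > 10000 nM in this assay, at which 4 of the 4 values shown sit.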